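The compounds below may be only part of what the source reports. "The series", "measured", "known", "first", "only" and "open" are said of these compounds alone.

In a functional assay on A549/CDDP cells (Homo sapiens) for antiproliferative activity, read by MTT assay, with a stated time of 72 h (a higher number here means a weaker inhibitor, a lower number a stronger inhibitor), compound 1 `COc1ccc(/C=C/C(=O)/C=C/c2nc(C)c(C)nc2C)cc1` gives 3610 nM, compound 2 `COc1ccc(/C=C/C(=O)/C=C/c2nc(C)c(C)nc2C)cc1OC` gives 2440 nM and compound 3 `COc1ccc(/C=C/C(=O)/C=C/c2nc(C)c(C)nc2C)c(OC)c1` gives 2850 nM. Compound 1 therefore stands level with the other two measured compounds. Compound 4 `Cc1ccc(/C=C/C(=O)/C=C/c2nc(C)c(C)nc2C)cc1` has methyl in place of methoxy on an aromatic carbon, para to a large group (methyl in place of methoxy on an aromatic carbon). Among the measured compounds shown here, no measured step makes this exact swap. The closest evidence is two methoxy-for-hydrogen changes, a 1.5-fold lower number from compound 1 to compound 2 (0.17 log units; within the scatter) and a 1.3-fold lower number from compound 1 to compound 3 (0.10 log units; within the scatter), and neither moves the value beyond the scatter. No shift beyond the scatter is therefore expected in this assay. The estimated step is a 1.1-fold lower number from compound 1 to compound 4 (0.04 log units; within the scatter), with no direction expected. Compound 4 is expected at 3300 nM, within an estimated range of 1600 nM to 6500 nM.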

Compound 4, half-maximal inhibitory concentration: 3990 nM
Beside the measured number, compound 4's estimate is 1.2-fold (0.08 log units) below it; the range from low to high includes it.
By their numbers in this assay, from the lowest: compounds 2, 3, 1 and 4 (each within the scatter of the next).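

In this assay, methyl in place of methoxy on the aromatic carbon para to a large group gives a step within the scatter (a 1.1-fold higher number from compound 1 to compound 4 (0.04 log units; within the scatter)). The earlier steps shown here only added a second methoxy to compound 1; this step changes the methoxy already present, and removing its oxygen moves no value beyond the scatter. No available evidence bears on this result.

On these data alone, it remains open whether an amine or a carboxylic acid at this position would shift the value beyond the scatter. As far as these compounds go, a longer chain, such as butoxy, also remains untested here.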